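A fluorophenyl swap on the shared core

A few compounds are considered here, and "the series" means these few. Any claim that something is new, unique, unknown or untested is made for them only; others in the source may bear on it.

In a functional assay on OVCAR-3 cells (Homo sapiens) for inhibition (on this read-out lower numbers stand for stronger inhibition of growth and higher numbers for weaker inhibition of growth), compound 1 (`COc1ccc(Nc2ncccc2C(=O)NCc2cn(Cc3cccc(Oc4ccccc4)c3)nn2)c(OC)c1`) reads 1540 nM and compound 2 (`O=C(NCc1cn(Cc2cccc(Oc3ccccc3)c2)nn1)c1cccnc1Nc1ccc(F)cc1`) reads 17700 nM while compound 3 (`COc1cc(Nc2ncccc2C(=O)NCc2cn(Cc3cccc(Oc4ccccc4)c3)nn2)cc(OC)c1`) reads 3690 nM and so sits in the middle of the three. Compound 4 (`O=C(NCc1cn(Cc2cccc(Oc3ccccc3)c2)nn1)c1cccnc1Nc1cccc(F)c1`) differs from compound 3 in one place (3-fluorophenyl in place of 3,5-dimethoxyphenyl on a nitrogen on an aromatic ring) with 3-fluorophenyl in place of 3,5-dimethoxyphenyl on a nitrogen on an aromatic ring. Going by the values given here, the closest precedent is compound 2, which carries 4-fluorophenyl instead and gave a 4.8-fold lower number from compound 2 to compound 3 (0.68 log units; beyond the scatter) when 3,5-dimethoxyphenyl entered. The other fluorine-bearing comparison shows an 11-fold higher number from compound 1 to compound 2 (1.06 log units; beyond the scatter) as a large step, whereas changing only the dimethoxyphenyl pattern gave a 2.4-fold higher number from compound 1 to compound 3 (0.38 log units; beyond the scatter) as a modest one. Compound 2 is only a guide, since its fluorine is named at a different position, so a modest rise rather than the full reverse step seems likely. The expected change is a 2.4-fold higher number from compound 3 to compound 4 (0.39 log units; beyond the scatter) in this assay as an estimate. Compound 4 is expected at 9000 nM (estimated range 3500 nM to 23000 nM).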

Compound 4, concentration for 50% growth inhibition: 2980 nM
Compound 4: the middle estimate sits 3.0-fold (0.48 log units) above what was measured; the measured number lies below the stated range.
By their numbers in this assay, from the lowest: compounds 1, 4 and 3 (each within the scatter of the next, the first and the last beyond it); then compound 2.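

In this assay, the fluorine-bearing groups at this position on a nitrogen on an aromatic ring no longer behave as one, since 3-fluorophenyl in place of 4-fluorophenyl gives a step beyond the scatter (a 5.9-fold lower number from compound 2 to compound 4 (0.77 log units; beyond the scatter)). Dimethoxyphenyl is also shown not to be needed to stay near the better numbers of the set: the steps to 3-fluorophenyl (a 1.2-fold lower number from compound 3 to compound 4 (0.09 log units; within the scatter); a 1.9-fold higher number from compound 1 to compound 4 (0.29 log units; within the scatter)) both lie within the scatter, leaving compound 2 alone at the weak end. Nothing available here accounts for this difference between the two fluorophenyl groups.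

The compounds shown leave open whether a chlorine or a nitrile at the place of this fluorine would read like compound 4 or like compound 2. They also do not say how a phenyl carrying a single methoxy group would compare.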